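The compounds below may be only part of what the source reports. "The series", "measured", "known", "first", "only" and "open" are said of these compounds alone.

Working notes on the series. Compound 1 `O=C1O/C(=C\Cn2cc(-c3ccc(Br)cc3)nn2)C(OCc2ccccc2)=C1OCc1ccccc1` and compound 2 `COc1ccccc1-c1cn(C[C@H](O)[C@H]2OC(=O)C(OCc3ccccc3)=C2OCc2ccccc2)nn1` share one core and differ in the group carried on the five-membered aromatic ring with three nitrogens. In a functional assay on MCF7 cells (Homo sapiens) for antiproliferative activity, read by MTT assay, with a stated time of 72 h (a lower number here means a stronger inhibitor, a higher number a weaker inhibitor), compound 1 gives only a limit of the assay, > 100000 nM. In this assay compound 2 likewise gives only a limit, > 100000 nM. Both known values sit at the same limit (the limit of > 100000 nM in this assay, at which 2 of the 2 values shown sit), so compound 2 stands at no measurable point on the numbers shown, and no step between measured compounds can be stated. Compound 3 `O=C1O[C@H]([C@@H](O)Cn2cc(CNS(=O)(=O)c3ccc(Cl)cc3)nn2)C(OCc2ccccc2)=C1OCc1ccccc1`, not yet measured, carries the change ((((4-chlorophenyl)sulfonyl)amino)methyl in place of 2-methoxyphenyl on an aromatic carbon). With both known values at a limit, the numbers give no direction for this change; the expected step is a number no higher from compound 2 to compound 3 (the limit leaves the size open), taken as none beyond the scatter. Compound 3 is therefore expected to give 100000 nM in this assay, with a range from 30000 nM to 300000 nM, most likely again only as a limit.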

Compound 3, half-maximal inhibitory concentration: 4170 nM
For compound 3 the middle estimate is 24-fold (1.38 log units) above the measured one; measured number below the stated range.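

In this assay, the group on the aromatic carbon of the five-membered aromatic ring with 3 nitrogen now proves able to move the number: (((4-chlorophenyl)sulfonyl)amino)methyl in place of 2-methoxyphenyl gives an at least 23-fold lower number from compound 2 to compound 3 (1.37 log units; beyond the scatter). Going by these compounds alone, this is the first measurable number, and the earlier compounds showed no difference at this position. From the compounds shown here alone, the true size of the step stays open, since compound 2 gives only a limit: the limit of > 100000 nM in this assay, at which 2 of the 3 values shown sit.

The compounds shown do not tell which part of the entering group carries the step, the chlorine, the sulfonyl group, the amide hydrogen or the methylene. A plain aminomethyl group, or the same sulfonylamino chain with an unsubstituted phenyl ring, would separate these parts.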